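The source may hold more compounds than are shown below. What is called first, only, known or untested is meant among the compounds shown, and "the series" means these compounds.

Compound 3 `COc1ccc(-c2cn3ccnc3c(-c3ccc4ncn(C5CCCCC5)c4c3)n2)cc1` stands highest of the three measured numbers in a functional assay on SK-MEL-5 cells (Homo sapiens) for inhibition, read by sulforhodamine B assay, with a stated time of 48 h, tested at 10 uM; a lower number here means less inhibition, a higher number more inhibition at the concentration tested (going by the name of the read-out): compound 3 gives 92.3%, while compound 2 `c1ccc(-c2cn3ccnc3c(-c3ccc4ncn(C5CCCCC5)c4c3)n2)cc1` gives 36.5% and compound 1 `Brc1cn2ccnc2c(-c2ccc3ncn(C4CCCCC4)c3c2)n1` gives 13.4%. The steps behind that ranking are a number 23.1 percentage points higher from compound 1 to compound 2 (beyond the scatter), a number 78.9 percentage points higher from compound 1 to compound 3 (beyond the scatter) and a number 55.8 percentage points higher from compound 2 to compound 3 (beyond the scatter). Compound 4 `O=Cc1ccc(-c2cn3ccnc3c(-c3ccc4ncn(C5CCCCC5)c4c3)n2)cc1` differs from compound 3 by formyl in place of methoxy on an aromatic carbon. For the measured compounds named here, the only measured step at this position is a number 55.8 percentage points higher from compound 2 to compound 3 (beyond the scatter), which shows that the methoxy carries most of the gain over compound 2; no measured step exchanges methoxy for formyl, so the expectation in this assay rests on loss of the methoxy alone. A fall of a number 37.3 percentage points lower from compound 3 to compound 4 (beyond the scatter) is expected, and compound 4 is estimated at 55% (range 25% to 85%).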

Compound 4, a percentage reported as inhibition, at one concentration (the size of the read-out at that concentration, not a potency): 56.5%
Compound 4: the middle estimate sits 1.5 percentage points below what was measured; low and high end bracket the measured number.
By their numbers in this assay, from the lowest: compound 1; then compound 2; then compound 4; then compound 3.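

In this assay, the group at this position does more than switch on activity: formyl in place of methoxy gives a number 35.8 percentage points lower from compound 3 to compound 4 (beyond the scatter), so the two groups are not interchangeable here. Even so, formyl in place of hydrogen gives a number 20 percentage points higher from compound 2 to compound 4 (beyond the scatter), so the gain over the unsubstituted phenyl is not confined to methoxy, and 4-formylphenyl in place of bromo gives a number 43.1 percentage points higher from compound 1 to compound 4 (beyond the scatter). Nothing at hand accounts for the gap between methoxy and formyl. From the compounds shown here alone, whether an amine, a carboxylic acid or a longer alkoxy chain such as ethoxy at this position would approach methoxy or formyl remains open.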